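Working notes: chloro for methyl on the way to compound 4

The source may report more compounds than this note shows. Statements on the series, on what has been measured and on what is new or still open speak of the compounds shown alone.

For the measured compounds named here, compound 2 `Cc1ccc(C(=O)c2cc(F)c(OCC(=O)NNC(=O)c3ccc(=O)oc3)c(Cl)c2)cc1` stands second highest of the three numbers so far in a functional assay on HeLa cells (Homo sapiens) for cytotoxicity, read by MTT assay, with a stated time of 48 h; a higher number here means a weaker inhibitor, a lower number a stronger inhibitor: compound 2 gives 20900 nM, compound 1 `O=C(COc1c(F)cc(C(=O)c2ccc(F)cc2)cc1Cl)NNC(=O)c1ccc(=O)oc1` gives 59900 nM, and compound 3 `Cc1ccc(C(=O)c2cc(F)c(OCC(=O)NNC(=O)c3cn(C)cn3)c(Cl)c2)cc1` gives 9900 nM. The nearest neighbour is compound 3, reached by a 2.1-fold lower number from compound 2 to compound 3 (0.32 log units; beyond the scatter); the furthest is compound 1, separated by a 2.9-fold lower number from compound 1 to compound 2 (0.46 log units; beyond the scatter).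

Compound 4 `O=C(COc1c(F)cc(C(=O)c2ccc(Cl)cc2)cc1Cl)NNC(=O)c1ccc(=O)oc1` differs from compound 2 by chloro in place of methyl on an aromatic carbon. Going by the values given here, only one measured step touches this aromatic carbon, a 2.9-fold lower number from compound 1 to compound 2 (0.46 log units; beyond the scatter), in which methyl replaced fluoro; no measured step exchanges methyl for chloro, and no compound carries chloro at this place. Among the compounds with values here, the data therefore give no fixed direction, and the size of the one step at this place is modest. The expected step of a 1.4-fold higher number from compound 2 to compound 4 (0.16 log units; within the scatter) in this assay is a small one, likely within the scatter, with a slight lean towards a higher number given that compound 1 with its halogen gave 59900 nM. Compound 4 is accordingly estimated at 30000 nM, with a range from 12000 nM to 75000 nM.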

Compound 4, half-maximal inhibitory concentration: 87100 nM
For compound 4 the middle estimate is 2.9-fold (0.46 log units) below the measured one; measured number outside the range, above it.
By their numbers in this assay, from the lowest: compound 3; then compound 2; then compounds 1 and 4 (each within the scatter of the next).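

In this assay, the exchange of 4-methylphenyl for 4-chlorophenyl is not a neutral swap: a 4.2-fold higher number from compound 2 to compound 4 (0.62 log units; beyond the scatter) is a step beyond the scatter, larger than the small change that had seemed likely at this place. Chloro and fluoro cannot be told apart here, since a 1.5-fold higher number from compound 1 to compound 4 (0.16 log units; within the scatter) lies within the scatter, so among these three compounds methyl stands apart from both halogens, as a 2.9-fold lower number from compound 1 to compound 2 (0.46 log units; beyond the scatter) also shows. No measured property is available to account for this difference.

On these data alone, whether a methoxy group, an amine or a bare hydrogen at this place would side with methyl or with the halogens stays open. Also open, as far as these compounds go, is whether the difference between methyl and chloro holds when the five-membered aromatic ring of compound 3 replaces the six-membered ring on the carbonyl carbon.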